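A few compounds are considered here, and "the series" means these few. Any claim that something is new, unique, unknown or untested is made for them only; others in the source may bear on it.

In a functional assay, read by spectrophotometry, tested at 100 uM (a higher number here means a weaker inhibitor, a lower number a stronger inhibitor), compound 1 (`O=C(/C=C/c1ccccc1Cl)c1cccc(NC(=O)c2cc(-c3ccncc3)n[nH]2)c1`) gives 27700 nM and compound 2 (`COc1cc(/C=C/C(=O)c2cccc(NC(=O)c3cc(-c4ccncc4)n[nH]3)c2)cc(OC)c1OC`) gives 54500 nM as its value, so compound 2 stands within the scatter of compound 1 and no order can be read between them. Compound 3 (`O=C(/C=C/c1ccc([N+](=O)[O-])cc1)c1cccc(NC(=O)c2cc(-c3ccncc3)n[nH]2)c1`) differs from compound 2 at one place (4-nitrophenyl in place of 3,4,5-trimethoxyphenyl on a double-bonded chain carbon bound to a double-bonded chain carbon), with 4-nitrophenyl in place of 3,4,5-trimethoxyphenyl on a double-bonded chain carbon bound to a double-bonded chain carbon. Among the measured compounds shown here, no measured compound carries 4-nitrophenyl. For the measured compounds named here, the one measured step at this place (a 2.0-fold higher number from compound 1 to compound 2 (0.29 log units; within the scatter)) put 3,4,5-trimethoxyphenyl in place of 2-chlorophenyl, so no step beyond the scatter is expected in this assay and no direction is favoured. The estimated step is small (a 1.4-fold lower number from compound 2 to compound 3 (0.13 log units; within the scatter)). Compound 3 is estimated at 40000 nM with 17000 nM to 90000 nM as the expected range.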

Compound 3, half-maximal inhibitory concentration: 52800 nM
Estimate against measurement, compound 3: 1.3-fold (0.12 log units) below, within the range that was stated.
By their numbers in this assay, from the lowest: compounds 1, 3 and 2 (each within the scatter of the next).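

At this place, on a double-bonded chain carbon bound to a double-bonded chain carbon, this assay does not separate 4-nitrophenyl from either earlier group: a 1.0-fold lower number from compound 2 to compound 3 (0.01 log units; within the scatter), and a 1.9-fold higher number from compound 1 to compound 3 (0.28 log units; within the scatter). The series now has three different substituted phenyl groups here, all within the scatter of one another, including a change from 3,4,5-trimethoxyphenyl with 12 heavy atoms to 4-nitrophenyl with 9 heavy atoms. No supporting measurement bears on why these groups read alike.

From the compounds shown here alone, all three compounds carry a substituted phenyl at this place, so it remains open whether an amine, a carboxylic acid or an unsubstituted phenyl here would give a step beyond the scatter. Also open, going by these compounds, is whether a longer chain in place of the double-bonded chain would shift the number.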